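Cyano on the phenyl of compound 2

This account rests on a few compounds, and the source may have more. Where it says the series, first, only, none or still open, it means among the compounds named here.

In a physicochemical assay for solubility, at pH 6.8 (on this read-out lower numbers stand for lower solubility and higher numbers for higher solubility), compound 1 `C[C@H](NC(=O)C1CCOCC1)c1ccc(NC(=O)[C@H]2C[C@@H]2c2cccnc2)cc1` gives 90000 nM. Compound 2 `C[C@H](NC(=O)c1ccccc1)c1ccc(NC(=O)[C@H]2C[C@@H]2c2cccnc2)cc1` gives < 4000 nM in this assay, which is a limit of the assay and not a number. Compound 2 therefore has no exact position, and it stands at the limit of < 4000 nM in this assay, at which 1 of the 2 values shown sits.

Compound 3 `C[C@H](NC(=O)c1ccc(C#N)cc1)c1ccc(NC(=O)[C@H]2C[C@@H]2c2cccnc2)cc1` departs from compound 2 by cyano in place of hydrogen on an aromatic carbon, with cyano in place of hydrogen on an aromatic carbon, para to a large group. The same difference reads phenyl to 4-cyanophenyl.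

Among the compounds with values here, only one measured step bears on this change, and it bears only indirectly: an at least 22-fold lower number from compound 1 to compound 2 (1.35 log units; beyond the scatter), with phenyl in place of oxan-4-yl on a carbonyl carbon. That step is large, but it swaps the whole group on the carbonyl and does not test a cyano group. Within the data shown here, no measured pair isolates that substitution, so no direction can be assigned with confidence. No shift beyond the scatter is expected, and a second limit reading is likely.

The expected step is a step that the limit leaves unreadable from compound 2 to compound 3. The estimated value for compound 3 is 3000 nM, with an expected range from 800 nM to 8000 nM.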

Compound 3, solubility: 175000 nM
For compound 3 the middle estimate is 58-fold (1.77 log units) below the measured one; the whole stated range lies below it.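

In this assay cyano in place of hydrogen on an aromatic carbon, para to a large group, brings an at least 43-fold higher number from compound 2 to compound 3 (1.64 log units; beyond the scatter), so a change of two heavy atoms on the phenyl is enough to lift the reading clear of the limit. The low reading therefore does not follow from having an aromatic ring on the carbonyl: beside an at least 22-fold lower number from compound 1 to compound 2 (1.35 log units; beyond the scatter) stands a 1.9-fold higher number from compound 1 to compound 3 (0.29 log units; within the scatter), so 4-cyanophenyl and oxan-4-yl on that carbonyl cannot be told apart on this read-out. The value of compound 2 is a limit and not a number, so the step to the cyano compound has a lower bound and no exact size: the limit of < 4000 nM in this assay, at which 1 of the 3 values shown sits.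

As far as these compounds go, whether the higher number is specific to cyano remains open, as a single substituent at a single position cannot separate that group from other groups on the same aromatic carbon, such as fluorine, methoxy, an amine or a carboxylic acid. It is equally unsettled whether cyano at another carbon of the phenyl, or on a different core, would give a step of similar size.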